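Adding a methoxy to the unsubstituted phenyl amide

This account rests on a few compounds, and the source may have more. Where it says the series, first, only, none or still open, it means among the compounds named here.

Of the compounds shown here, three that share one core have been measured in an assay on cells for displacement of a labelled ligand from Neuronal acetylcholine receptor; alpha3/beta4 (Homo sapiens); a lower number here means a stronger inhibitor, a higher number a weaker inhibitor. Compound 1 `O=C(Nc1cccc(F)c1)c1cncc(N2CC3CC(C2)N3)c1` gives 28 nM, compound 2 `O=C(Nc1ccccc1F)c1cncc(N2CC3CC(C2)N3)c1` gives 102 nM, and compound 3 `O=C(Nc1ccccc1)c1cncc(N2CC3CC(C2)N3)c1` gives 192 nM. Compound 3 thus has the highest number of the three: the gap to compound 2 lies within the scatter, while the gap to compound 1 is clearly beyond it, as the step of a 6.9-fold higher number from compound 1 to compound 3 (0.84 log units; beyond the scatter) shows.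

Compound 4 `COc1cccc(NC(=O)c2cncc(N3CC4CC(C3)N4)c2)c1` has not yet been measured. It differs from compound 3 by methoxy in place of hydrogen on an aromatic carbon. Going by the values given here, no measured step involves a methoxy, so the only guide is that a fluoro on the same ring, the change a 6.9-fold higher number from compound 1 to compound 3 (0.84 log units; beyond the scatter), moved the number clearly, and that placing fluoro differently, a 3.6-fold higher number from compound 1 to compound 2 (0.56 log units; beyond the scatter), mattered too. Because a substituent there helped in a 6.9-fold higher number from compound 1 to compound 3 (0.84 log units; beyond the scatter), a gain is expected for compound 4, but a smaller one, since methoxy is an untested group. Compound 4 is therefore estimated at 70 nM, with a plausible range from 25 nM to 200 nM; this expected step is a 2.7-fold lower number from compound 3 to compound 4 (0.44 log units; beyond the scatter).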

Compound 4, inhibition constant: 265 nM
For compound 4 the middle estimate is 3.8-fold (0.58 log units) below the measured one; the whole stated range lies below it.
By their numbers in this assay, from the lowest: compound 1; then compounds 2, 3 and 4 (each within the scatter of the next, the first and the last beyond it).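

In this assay, the step to the methoxy group, a 1.4-fold higher number from compound 3 to compound 4 (0.14 log units; within the scatter), shows that simply putting a substituent on this ring carbon does not lower the number: the 3-methoxyphenyl amide cannot be told apart from the plain phenyl amide. What counts on this carbon is which group sits there, since exchanging fluoro for methoxy gives a 9.5-fold higher number from compound 1 to compound 4 (0.98 log units; beyond the scatter). The 3-methoxyphenyl amide also stands apart from the 2-fluorophenyl amide, with a 2.6-fold higher number from compound 2 to compound 4 (0.41 log units; beyond the scatter), even though the plain phenyl amide of compound 3 lies within the scatter of both.

Nothing available here explains why fluoro and methoxy differ on this carbon. As far as these compounds go, it remains open whether a chloro, a hydroxyl or an amine on the same carbon would behave more like fluoro or more like methoxy.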